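Swapping nitro for hydroxy on the substituted ring

The compounds below may be only part of what the source reports. "The series", "measured", "known", "first", "only" and "open" are said of these compounds alone.

Within the data shown here, in a functional assay on MDA-MB-231 cells (Homo sapiens) for antiproliferative activity, read by MTT assay, with a stated time of 72 h (on this read-out higher numbers stand for weaker inhibition and lower numbers for stronger inhibition), compound 1 `COc1ccc(-n2ccnc2-c2cc(OC)c(OC)c(OC)c2)cc1[N+](=O)[O-]` gives 7500 nM, the only true number so far. Compound 2 `COc1cc(-c2nccn2-c2cccc([N+](=O)[O-])c2)cc(OC)c1OC`, with hydrogen in place of methoxy, gives > 100000 nM, which is a limit of the assay and not a number. The measured change is an at least 13-fold higher number from compound 1 to compound 2 (1.12 log units; beyond the scatter), large and beyond the scatter.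

Compound 3 `COc1ccc(-n2ccnc2-c2cc(OC)c(OC)c(OC)c2)cc1O` differs from compound 1 by hydroxy in place of nitro on an aromatic carbon, ortho to a methoxy group. Among the measured compounds shown here, no measured step touches the nitro itself. Still, an at least 13-fold higher number from compound 1 to compound 2 (1.12 log units; beyond the scatter) shows that one swap on this ring can move the number far, so a sizeable step is expected in this assay, towards stronger inhibition, though this direction is uncertain. The expected change is a 15-fold lower number from compound 1 to compound 3 (1.18 log units; beyond the scatter). For compound 3 the estimate is 500 nM, with an expected range of 30 nM to 8000 nM.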

Compound 3, half-maximal inhibitory concentration: 1900 nM
Compound 3: middle estimate off by 3.8-fold (0.58 log units), on the low side, and the stated range covers the measured number.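

In this assay, the place on this ring ortho to a methoxy group now has its first direct reading, and the nitro group there can be replaced without the activity being lost: hydroxy in place of nitro gives a 3.9-fold lower number from compound 1 to compound 3 (0.60 log units; beyond the scatter). Among these compounds, this step lowers the number, whereas the only earlier step, hydrogen in place of the methoxy group, raised it, so changes on this ring can move the number in either direction. Compound 2 carries a limit of the assay and not a number, so the earlier step has no exact size: the limit of > 100000 nM in this assay, at which 1 of the 3 values shown sits.

From the compounds shown here alone, what an amine or a carboxylic acid would do in place of the hydroxy stays open. Also open, going by these compounds, is whether hydroxy would still give a lower number with hydrogen in place of the neighbouring methoxy group.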